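Fluoro for Methoxy at the Least Inhibiting Compound

The source may hold more compounds than are shown below. What is called first, only, known or untested is meant among the compounds shown, and "the series" means these compounds.

Compound 3 `COc1ccccc1-c1cn2ccnc2c(-c2ccc3ncn(C4CCCCC4)c3c2)n1` stands lowest of the three measured compounds in a functional assay on NCI/ADR-RES cells (Homo sapiens) for inhibition, read by sulforhodamine B assay, with a stated time of 48 h, tested at 10 uM; on this read-out lower numbers stand for less inhibition and higher numbers for more inhibition at the one concentration tested (going by the name of the read-out): compound 3 gives 0.06%, while compound 1 `c1ccc(-c2cn3ccnc3c(-c3ccc4ncn(C5CCCCC5)c4c3)n2)cc1` gives 50.5% and compound 2 `O=Cc1ccc(-c2cn3ccnc3c(-c3ccc4ncn(C5CCCCC5)c4c3)n2)cc1` gives 37.4%. Compound 4 `Fc1ccccc1-c1cn2ccnc2c(-c2ccc3ncn(C4CCCCC4)c3c2)n1` differs from compound 3 as fluoro in place of methoxy on an aromatic carbon. Among the compounds with values here, no measured step exchanges fluoro for methoxy; the steps that bear on it are a number 50.4 percentage points lower from compound 1 to compound 3 (beyond the scatter) and a number 37.3 percentage points lower from compound 2 to compound 3 (beyond the scatter), both large and both ending at the methoxy compound. Compound 4 sheds that methoxy, so part of the loss seen in a number 50.4 percentage points lower from compound 1 to compound 3 (beyond the scatter) is expected to be recovered, though the floor leaves little room downward. Compound 4 is therefore expected to rise by a number 19.9 percentage points higher from compound 3 to compound 4 (beyond the scatter). The estimate for compound 4 is 20%, ranging from 0% to 48%.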

Compound 4, a percentage reported as inhibition, at one concentration (the size of the read-out at that concentration, not a potency): 4.51%
For compound 4 the middle estimate is 15.5 percentage points above the measured one; measured number inside the range.
By their numbers in this assay, from the lowest: compounds 3 and 4 (each within the scatter of the next); then compound 2; then compound 1.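

In this assay, methoxy and fluoro cannot be told apart at this place, ortho to a large group: a number 4.5 percentage points higher from compound 3 to compound 4 (within the scatter). The low number therefore does not belong to methoxy alone, since fluoro in place of hydrogen gives a number 46 percentage points lower from compound 1 to compound 4 (beyond the scatter) and 2-fluorophenyl in place of 4-formylphenyl gives a number 32.9 percentage points lower from compound 2 to compound 4 (beyond the scatter). Nothing available explains this loss.

The compounds shown leave open whether any group at this place keeps the number of compound 1. An amine, a hydroxyl or a methyl there could settle this.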